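Phenyl in Place of Dichlorophenyl on the Aryl Nitrogen

A few compounds are considered here, and "the series" means these few. Any claim that something is new, unique, unknown or untested is made for them only; others in the source may bear on it.

Of the compounds shown here, two sharing one core have been measured in an assay for inhibition of leukotriene C4 synthase (Homo sapiens), read by LC-MS, with stated times of 15 min and 30 min; on this read-out lower numbers stand for stronger inhibition and higher numbers for weaker inhibition. Compound 1 `COc1cc(N(CC2CC2)c2ccc(Cl)c3ccccc23)cnc1C(=O)[C@H]1C[C@@H]1C(=O)O` carries a chloronaphthyl group on the nitrogen and gives 1.41 nM in this assay. Compound 2 `COc1cc(N(CC2CC2)c2ccc(Cl)c(Cl)c2)cnc1C(=O)[C@H]1C[C@@H]1C(=O)O` carries a 3,4-dichlorophenyl group in the same place and gives 4.94 nM in this assay, the higher of the two numbers, standing beyond the scatter from compound 1.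

The next compound, compound 3 `COc1cc(N(CC2CC2)c2ccccc2)cnc1C(=O)[C@H]1C[C@@H]1C(=O)O`, is obtained from compound 2 by the change (phenyl in place of 3,4-dichlorophenyl on a nitrogen on an aromatic ring). For the measured compounds named here, no measured pair shows a change of this kind, so its size can only be expected, not read from the data. Both measured compounds carry chlorine on the aryl group attached to the nitrogen, and the weaker of them, compound 2, already stands beyond the scatter from compound 1. The author expects the step from compound 2 to compound 3 to run toward weaker inhibition, by roughly a 4.0-fold higher number from compound 2 to compound 3 (0.61 log units; beyond the scatter) in this assay. Compound 3 is therefore estimated at 20 nM in this assay, within a range of 7 nM to 60 nM.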

Compound 3, half-maximal inhibitory concentration: 158 nM
For compound 3 the middle estimate is 7.9-fold (0.90 log units) below the measured one, and the stated range ends below it.
By their numbers in this assay, from the lowest: compound 1; then compound 2; then compound 3.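

In this assay, the change from 3,4-dichlorophenyl to phenyl on the nitrogen gives a 32-fold higher number from compound 2 to compound 3 (1.50 log units; beyond the scatter) and leaves the rest of the molecule untouched, so the two chlorine atoms that leave are the whole of the difference. Until now, the aryl groups compared at this position both carried chlorine, with compound 1 at 1.41 nM and compound 2 at 4.94 nM, so those numbers could not show what the position does without it; compound 3 shows that inhibition in this series depends heavily on the chlorine atoms of this aryl group, and that the bare phenyl group is much weaker. No measurement at hand explains why the loss is this large.

The compounds shown leave open whether the two chlorine atoms contribute equally or one of them accounts for most of the step, which a phenyl group bearing a single chlorine would address. They also leave open whether fluorine, methyl or trifluoromethyl on the phenyl group could take the place of chlorine and restore inhibition at this position.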